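Halophenyl series: cytotoxicity step from compound 3 to compound 4

This account rests on a few compounds, and the source may have more. Where it says the series, first, only, none or still open, it means among the compounds named here.

Compound 3 `O=C1CSC(c2cccc(F)c2)N1CCN1CCCCC1` stands level with compound 1 `O=C1CSC(c2cccc(Cl)c2)N1CCN1CCCCC1` and compound 2 `O=C1CSC(c2ccc(F)cc2)N1CCN1CCCCC1` on the one read-out available. In an ADME assay on Vero cells (Chlorocebus sabaeus) for cytotoxicity, read by neutral red uptake, tested at 12.3 ug/mL (a higher number here means a weaker effect of the compound at the concentration tested, a lower number a stronger effect), compound 3 gives 100%; compound 1 gives 100%; compound 2 gives 100%. The three single-point steps are all flat: no change at the digits printed from compound 1 to compound 2 (within the scatter), no change at the digits printed from compound 1 to compound 3 (within the scatter) and no change at the digits printed from compound 2 to compound 3 (within the scatter). Neither swapping chloro for fluoro on the aromatic carbon nor moving the halogen between the ring positions shifts the value at this concentration.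

Compound 4 `O=C1CSC(c2ccc(Cl)cc2)N1CCN1CCCCC1` differs from compound 3 in one place: 4-chlorophenyl in place of 3-fluorophenyl on a saturated ring carbon. The step combines the two kinds of change already seen, the halogen swap of no change at the digits printed from compound 1 to compound 3 (within the scatter) and the position move of no change at the digits printed from compound 2 to compound 3 (within the scatter), both of which were without effect. No step in this assay gives reason to expect a departure. For compound 4 the expected value in this assay is 100%, with a range from 90% to 105%. Expected, therefore, is a step of no change at the digits printed from compound 3 to compound 4 (within the scatter), nothing beyond the scatter.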

Compound 4, a percentage reported as activity, at one concentration (the size of the read-out at that concentration, not a potency): 90%
Compound 4: middle estimate off by 10 percentage points, on the high side; low and high end bracket the measured number.
By their numbers in this assay, from the lowest: compounds 4, 1, 2 and 3 (each within the scatter of the next).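

In this assay, within the data shown here, 4-chlorophenyl on the saturated ring carbon gives the first steps of printed size in this set, yet all three stay inside the scatter: a number 10 percentage points lower from compound 3 to compound 4 (within the scatter), a number 10 percentage points lower from compound 2 to compound 4 (within the scatter) and a number 10 percentage points lower from compound 1 to compound 4 (within the scatter). Among these four compounds, therefore, neither the exchange of fluoro and chloro on the aromatic carbon nor the change from 3-chlorophenyl to 4-chlorophenyl gives a step beyond the scatter. The exchange of fluoro and chloro can now be compared in two settings, and the two steps do not separate: the same change on two cores in this assay, no change at the digits printed (within the scatter) from compound 1 to compound 3 and a number 10 percentage points higher (within the scatter) from compound 4 to compound 2, 10 percentage points apart, within the scatter of two such steps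

From the compounds shown here alone, whether an amine or a carboxylic acid on the phenyl ring, in place of the halogen, would give a step beyond the scatter remains open. The read-out at one concentration gives the size of the effect there, not a potency, so the behaviour of these compounds at other concentrations also remains open.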